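Cyano to nitro in a weak antiproliferative compound

A few compounds are considered here, and "the series" means these few. Any claim that something is new, unique, unknown or untested is made for them only; others in the source may bear on it.

Measured so far in a functional assay on DU-145 cells (Homo sapiens) for antiproliferative activity, read by propidium iodide staining, with a stated time of 96 h; on this read-out lower numbers stand for stronger inhibition and higher numbers for weaker inhibition:
compound 1 `CC(O)(CSc1cccc(OC(F)(F)F)c1)C(=O)Nc1cccc(S(F)(F)(F)(F)F)c1`: 25000 nM
compound 2 `CC1(C)C(=O)N(c2ccc(C#N)cc2C(F)(F)F)C(=S)N1c1cccc(S(F)(F)(F)(F)F)c1`: 100000 nM

For the measured compounds named here, with only two measured compounds, the picture is small. Compound 2 gives 100000 nM as the higher of the two numbers, so it is the weaker of the pair. Compound 1 gives 25000 nM as the lower number, and the gap between them lies beyond the scatter of repeated measurements.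

The next compound is compound 3 `CC1(C)C(=O)N(c2ccc([N+](=O)[O-])cc2C(F)(F)F)C(=S)N1c1cccc(S(F)(F)(F)(F)F)c1`, which keeps the rest of compound 2 and alters a single group: nitro in place of cyano on an aromatic carbon. In plain terms, this puts nitro in place of cyano on an aromatic carbon.

Going by the values given here, no pair of measured compounds shows this swap or any other single alteration, so the data give no direct guide. The expectation therefore starts from compound 2 at 100000 nM as the closest measured neighbour. The estimated size is a 1.4-fold lower number from compound 2 to compound 3 (0.15 log units; within the scatter) in this assay, so no step beyond the scatter is expected. For compound 3 the estimated value is 70000 nM with an expected range from 25000 nM to 150000 nM on this measure.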

Compound 3, half-maximal inhibitory concentration: 100000 nM
The estimate for compound 3 lay 1.4-fold (0.15 log units) below the measured number, and the stated range covers the measured number.
By their numbers in this assay, from the lowest: compound 1; then compounds 2 and 3 (each within the scatter of the next).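

Putting nitro in place of cyano on the aromatic carbon gives no change at the digits printed from compound 2 to compound 3 (within the scatter) in this assay. This is the first pair shown that differs in only one place, and it gives a direct reading at this position, meta to a trifluoromethyl group and para to a large group: nitro, with 3 heavy atoms and 2 hydrogen-bond acceptors, and cyano, with 2 heavy atoms and 1 acceptor, cannot be told apart on this measure, and neither brings the number down from the high level of this pair. Nothing available explains why the two groups read alike.

The compounds shown leave open whether any other group on this aromatic carbon, such as an amine, a carboxylic acid or a methoxy group, would separate from these two by more than the scatter. They also leave open whether the same swap would read alike on a compound with a much lower number, since a single pair cannot show how far this result carries to other compounds.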